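Demethylation of the aryl ether in a tetrahydroquinoline amide series

This account rests on a few compounds, and the source may have more. Where it says the series, first, only, none or still open, it means among the compounds named here.

Measured compounds:
- compound 1, `COc1ccc(NC(=O)C2CCc3ccccc3N2)cc1`: 38000 nM
- compound 2, `O=C(Nc1ccccc1O)C1CCc2ccccc2N1`: 3990 nM
- compound 3, `O=C(Nc1ccccc1C(F)(F)F)C1CCc2ccccc2N1C(=O)c1ccccc1Cl`: 3900 nM

In a functional assay on ACHN cells (Homo sapiens) for cytotoxicity, read by sulforhodamine B assay, with a stated time of 72 h (on this read-out higher numbers stand for weaker inhibition of growth and lower numbers for stronger inhibition of growth), compound 1 gives the highest number of the three, with compound 2 and compound 3 each sitting beyond the scatter below it, and the gap between those two lying within the scatter. For the measured compounds named here, no pairwise step between measured compounds is available, since none of them differ in a single place; compound 2 carries a hydroxy on the amide-bearing ring in place of the methoxy of compound 1, but at a different position on that ring, and compound 3 carries an acyl group on the ring nitrogen of the core as well as a different substituent on the anilide.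

The next compound, compound 4, `O=C(Nc1ccc(O)cc1)C1CCc2ccccc2N1`, differs from compound 1 in a single place:

hydrogen in place of methyl on an oxygen on an aromatic ring

Compound 2 shows that a hydroxy-bearing anilide can reach 3990 nM, so a move downward from compound 1 is plausible, though the hydroxy there sits elsewhere on the ring. The step in this assay from compound 1 to compound 4 is expected to be a modest decrease, a 2.5-fold lower number from compound 1 to compound 4 (0.40 log units; beyond the scatter), probably beyond the scatter but not approaching compound 2. Compound 4 is therefore estimated at 15000 nM, with a range from 5000 nM to 45000 nM.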

Compound 4, concentration for 50% growth inhibition: > 100000 nM
Compound 4: no number, only a limit (the forecaster's own chance of this, stated with the estimate: 5%); middle value at least 6.6-fold (0.82 log units) from the limit.
By their numbers in this assay, from the lowest: compounds 3 and 2 (each within the scatter of the next); then compound 1. At a limit, above all of these: compound 4.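

In this assay compound 4 gives > 100000 nM, which is a limit of the assay and not a number. For the compounds shown here, the first single-place step, hydrogen in place of methyl on an oxygen on an aromatic ring, gives an at least 2.6-fold higher number from compound 1 to compound 4 (0.42 log units; beyond the scatter), so at this oxygen the methoxy to hydroxy change moves the read-out toward weaker inhibition of growth, and the loss of that one carbon is enough to do so. The step is a minimum only, and its full size cannot be read: the limit of > 100000 nM in this assay, at which 1 of the 4 values shown sits.

The compounds shown leave open whether a longer chain on this oxygen, such as ethyl, or an amine in place of the oxygen would bring the number down again or push it up further. Also open, on these data alone, is how a methyl on the hydroxy oxygen of compound 2 would read, and so whether the same change runs in the same direction elsewhere on the anilide ring.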